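From 4-fluorobenzyl to 2-nitrobenzyl on a shared core

The compounds below may be only part of what the source reports. "The series", "measured", "known", "first", "only" and "open" are said of these compounds alone.

Measured so far in an ADME assay on MT4 cells (Homo sapiens) for cytotoxicity, read by MTT assay (a lower number here means that less compound is tolerated, a higher number that more compound is tolerated), for this series
- compound 1 `COc1ccc(CNC(=O)c2[nH]c3ccc(Cl)cc3c2S(=O)(=O)c2cc(C)cc(C)c2)cc1` gives the number 39900 nM here
- compound 2 `Cc1cc(C)cc(S(=O)(=O)c2c(C(=O)NCc3cccc(F)c3)[nH]c3ccc(Cl)cc23)c1` gives > 53000 nM as a limit
- compound 3 `Cc1cc(C)cc(S(=O)(=O)c2c(C(=O)NCc3ccc(F)cc3)[nH]c3ccc(Cl)cc23)c1` gives > 53000 nM as a limit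

Compound 3 stands at a limit, > 53000 nM in this assay, and has no exact number. The series offers the limit of > 53000 nM in this assay, at which 2 of the 3 values shown sit, and nothing more exact at that end.

Compound 4 `Cc1cc(C)cc(S(=O)(=O)c2c(C(=O)NCc3ccccc3[N+](=O)[O-])[nH]c3ccc(Cl)cc23)c1` carries 2-nitrophenyl in place of 4-fluorophenyl on a saturated chain carbon bound to an amide-type nitrogen and the same difference reads as 4-fluorobenzyl to 2-nitrobenzyl.

Among the compounds with values here, three measured steps touch this same place. The series shows an at least 1.3-fold higher number from compound 1 to compound 2 (0.12 log units; that floor lies within the scatter) and also an at least 1.3-fold higher number from compound 1 to compound 3 (0.12 log units; that floor lies within the scatter) as floors, while the third is a step that the two limits leave unreadable from compound 2 to compound 3 and gives no size. Within the data shown here, no measured compound carries 2-nitrophenyl. Among the measured compounds shown here, compound 1 at 39900 nM shows only that a readable number can occur with a change at this place.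

The expected result is an at least 1.1-fold lower number from compound 3 to compound 4 (0.07 log units; that floor lies within the scatter) in this assay and no step beyond the scatter is foreseen, though a further limit reading is quite possible. Compound 4 is expected at 45000 nM with 20000 nM to 75000 nM as the estimated range.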

Compound 4, half-maximal cytotoxic concentration: > 50200 nM
Compound 4 was reported as a limit; the forecaster's own chance of this, stated with the estimate: 50%; at least 1.1-fold (0.04 log units) between middle value and limit.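

In this assay compound 4 also gives only a limit, > 50200 nM, so 2-nitrophenyl joins 3-fluorophenyl and 4-fluorophenyl as a group at this place without an exact number. Replacing 4-methoxyphenyl with 2-nitrophenyl gives an at least 1.2-fold higher number from compound 1 to compound 4 (0.09 log units; that floor lies within the scatter), which shows no difference beyond the scatter. The steps from compound 2 and compound 3 to compound 4 cannot be read. Limits stand on both sides of these steps. The new result adds a second limit to the series, so three of the four compounds now lack an exact number: the limit of > 50200 nM in this assay, at which 1 of the 4 values shown sits.

The compounds shown leave open whether compound 2, compound 3 and compound 4 differ from one another, or from compound 1 beyond the scatter, once exact numbers are available. They also leave open how a 2-aminophenyl group, a 2-carboxyphenyl group or a longer chain would read at this place.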